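Chloro for hydrogen on two related anticonvulsant-type cores

The compounds below may be only part of what the source reports. "The series", "measured", "known", "first", "only" and "open" are said of these compounds alone.

Measured so far:
compound 1, `Cn1ncc2c1NC(=O)CN=C2c1ccccc1`, > 80 mg/kg in a functional assay on the whole organism (strain Holtzman) with Rattus norvegicus as the target; on this read-out lower numbers stand for an effect already at smaller amounts and higher numbers for an effect only at larger amounts of compound;
compound 2, `Cn1nc(Cl)c2c1NC(=O)CN=C2c1ccccc1`, 40 mg/kg;
compound 3, `Cc1nn(-c2ccccc2)c2c1C(c1ccccc1)=NCC(=O)N2`, > 40 mg/kg.

For compound 1 the value is a limit of this assay, not a number, the one given as the limit of > 80 mg/kg in this assay, at which 1 of the 3 values shown sits. For compound 3 the value is likewise a limit, the one given as the limit of > 40 mg/kg in this assay, at which 1 of the 3 values shown sits. Compound 2 gives a number, and the change chloro in place of hydrogen on an aromatic carbon made the step of an at least 2.0-fold lower number from compound 1 to compound 2 (0.30 log units; that floor lies within the scatter).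

Compound 4, `Cc1nn(-c2ccccc2)c2c1C(c1ccccc1Cl)=NCC(=O)N2`, is not yet measured. It differs from compound 3 by chloro in place of hydrogen on an aromatic carbon, the same kind of change as from compound 1 to compound 2, though the place differs: there the chloro sits on a five-membered aromatic ring with 2 nitrogen, here on a six-membered aromatic ring of carbon only, ortho to a large group. The difference between the two cores is not broken down here. Since compound 3 gives only a limit, the expected step of an at least 1.3-fold lower number from compound 3 to compound 4 (0.12 log units; that floor lies within the scatter) rests loosely on the earlier step; compound 4 is estimated at 30 mg/kg, between 10 mg/kg and 80 mg/kg.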

Compound 4, minimum effective dose: 20 mg/kg
The estimate for compound 4 lay 1.5-fold (0.18 log units) above the measured number, and the stated range covers the measured number.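

In this assay, putting chloro in place of hydrogen on the phenyl ring gives an at least 2.0-fold lower number from compound 3 to compound 4 (0.30 log units; that floor lies within the scatter). Set beside the earlier step, the change goes the same way on both cores, though neither floor clears the usual scatter: the same change on two cores in this assay, an at least 2.0-fold lower number (0.30 log units; that floor lies within the scatter) from compound 1 to compound 2 and an at least 2.0-fold lower number (0.30 log units; that floor lies within the scatter) from compound 3 to compound 4; the limit leaves it open whether they differ

Compound 3 is recorded only as a limit, > 40 mg/kg, and this pair of cores, with chloro at different places, does not show that the change carries across the whole series.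

The compounds shown leave open whether a methoxy group or an amine in place of the chloro would give a similar number. They also leave open whether phenyl to 2-chlorophenyl on the core of compound 1 would give a step of similar size.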